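From a bromine to a fluorine on the pendant phenyl

The source may hold more compounds than are shown below. What is called first, only, known or untested is meant among the compounds shown, and "the series" means these compounds.

In an assay for inhibition of Intestinal-type alkaline phosphatase (Homo sapiens), read by spectrophotometry, with stated times of 10 min and 20 min (a lower number here means a stronger inhibitor, a higher number a weaker inhibitor), compound 3 `O=C1/C(=C/c2ccc(Br)cc2)NS(=O)(=O)c2ccccc21` gives 3690 nM, the second highest of the three numbers measured. Compound 2 `O=C1/C(=C/c2ccccc2Br)NS(=O)(=O)c2ccccc21` gives 7430 nM, and the step of a 2.0-fold lower number from compound 2 to compound 3 (0.30 log units; within the scatter) lies within the scatter. Compound 1 `COc1cccc(/C=C2\NS(=O)(=O)c3ccccc3C2=O)c1` gives 1040 nM, a lower number than compound 3 by more than the scatter. Compound 4 `O=C1/C(=C/c2cccc(F)c2)NS(=O)(=O)c2ccccc21` differs from compound 3 by 3-fluorophenyl in place of 4-bromophenyl on a double-bonded chain carbon bound to a double-bonded ring carbon. Within the data shown here, no measured step exchanges a bromine for a fluorine; the only related step, a 2.0-fold lower number from compound 2 to compound 3 (0.30 log units; within the scatter), stays within the scatter. Because compound 3 gives 3690 nM and is the closest guide, compound 4 is expected near it, a step of a 1.2-fold lower number from compound 3 to compound 4 (0.09 log units; within the scatter) not beyond the scatter. The estimate for compound 4 is 3000 nM, with a range from 1000 nM to 9000 nM.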

Compound 4, half-maximal inhibitory concentration: 9930 nM
The estimate for compound 4 lay 3.3-fold (0.52 log units) below the measured number; the measured number lies above the stated range.
By their numbers in this assay, from the lowest: compound 1; then compounds 3, 2 and 4 (each within the scatter of the next, the first and the last beyond it).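

Replacing 4-bromophenyl with 3-fluorophenyl on this double-bonded chain carbon gives a step beyond the scatter in this assay (a 2.7-fold higher number from compound 3 to compound 4 (0.43 log units; beyond the scatter)), unlike the earlier move of bromine from 2-bromophenyl to 4-bromophenyl. Replacing 2-bromophenyl with 3-fluorophenyl stays within the scatter (a 1.3-fold higher number from compound 2 to compound 4 (0.13 log units; within the scatter)), while fluoro in place of methoxy on an aromatic carbon gives the widest step here (a 9.5-fold higher number from compound 1 to compound 4 (0.98 log units; beyond the scatter)). No available evidence accounts for these differences. Still open, going by these compounds, is how 3-bromophenyl would compare with 3-fluorophenyl, and how an amine or a carboxylic acid on the phenyl would compare with methoxy.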